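The source may hold more compounds than are shown below. What is called first, only, known or untested is meant among the compounds shown, and "the series" means these compounds.

Measured compounds:
compound 1, `Cc1nn(-c2ncnc3nc[nH]c23)c2c1C(C(=O)NCc1ccccc1)CC(=O)N2` — 2930 nM
compound 2, `Cc1cc(C)nc(-n2nc(C)c3c2NC(=O)CC3c2ccc(COc3cccc(Cl)c3)cc2)n1` — 3000 nM

Of the compounds shown here, two have been measured in a functional assay on HEK293 cells for agonist activity at G-protein coupled receptor 39 (Homo sapiens), read by scintillation proximity assay and inositol phosphate accumulation, with a stated time of 75 min; on this read-out lower numbers stand for an effect already at smaller amounts and higher numbers for an effect only at larger amounts of compound. Compound 1 gives 2930 nM there, and compound 2 gives 3000 nM; the two numbers sit within the usual scatter of one another, so neither compound stands apart from the other, and compound 1 holds no distinguished place on these numbers.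

Compound 3, `Cc1nn(-c2ncnc3nc[nH]c23)c2c1C(OCC(C)C)CC(=O)N2`, has not yet been measured. It differs from compound 1 in one place: isobutoxy in place of benzylcarbamoyl on a saturated ring carbon. Within the data shown here, compound 2 shares no single-point relation with either of them, so no measured step exists to show how this kind of exchange plays out in this assay.

With nothing to anchor the change, the expectation rests only on its size: a larger group with a ring gives way to a short open chain, and the amide hydrogen is lost. Compound 3 is therefore expected to need a somewhat larger amount than compound 1, with an estimated step of a 2.4-fold higher number from compound 1 to compound 3 (0.38 log units; beyond the scatter), and an estimated value of 7000 nM, in the range 2000 nM to 25000 nM.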

Compound 3, half-maximal effective concentration: 111 nM
For compound 3 the middle estimate is 63-fold (1.80 log units) above the measured one, outside the stated range (below it).
By their numbers in this assay, from the lowest: compound 3; then compounds 1 and 2 (each within the scatter of the next).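

In this assay, among these compounds, isobutoxy in place of benzylcarbamoyl on the saturated ring carbon gives a 26-fold lower number from compound 1 to compound 3 (1.42 log units; beyond the scatter), the first measured step at this position. The two earlier compounds, whose numbers lay within the scatter of each other and which share no single-point relation, could not show that the read-out responds so strongly to what this carbon carries. On the core of compound 1, benzylcarbamoyl, with its six-membered aromatic ring and its hydrogen-bond donor, is thus not required for an effect at smaller amounts, and the open chain of 5 heavy atoms does better, although no measurement at hand explains the size of this step.

The single exchange removes the ring, the amide and the hydrogen-bond donor together and brings in the ether oxygen, so the compounds shown do not separate the share of each of these changes. From the compounds shown here alone, how a benzyl ether, a longer alkoxy chain, a plain alkyl chain or an amine on the same ring carbon would read in this assay remains open.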